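Swapping the Aryl Group on a Dopamine Receptor Series

The source may hold more compounds than are shown below. What is called first, only, known or untested is meant among the compounds shown, and "the series" means these compounds.

Of the compounds shown here, three built on one shared core have been tested in a functional assay on HEK293 cells for agonist activity at D(4) dopamine receptor (Homo sapiens), read by FLIPR; a higher number here means a larger maximal response, a lower number a smaller maximal response. Compound 1 `Cc1cc(C(=O)NCN2CCC(c3cccc[n+]3[O-])CC2)ccc1F` gives 67% in this assay. Compound 2 `N#Cc1cccc(C(=O)NCN2CCC(c3cccc[n+]3[O-])CC2)c1` gives 69%, and compound 3 `Cc1ccc(C(=O)NCN2CCC(c3cccc[n+]3[O-])CC2)cc1C` gives 65%. The three numbers sit close together: a number 2 percentage points higher from compound 1 to compound 2 (within the scatter), a number 2 percentage points lower from compound 1 to compound 3 (within the scatter), and a number 4 percentage points lower from compound 2 to compound 3 (within the scatter). Compound 3 thus stands alongside the other two, with no gap that the measurement could separate from ordinary scatter.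

Compound 4 `O=C(NCN1CCC(c2cccc[n+]2[O-])CC1)c1cc(Cl)cc(Cl)c1` differs from compound 3 at the group on the carbonyl carbon: 3,5-dichlorophenyl in place of 3,4-dimethylphenyl on a carbonyl carbon. Two of the measured steps concern the same kind of exchange, a whole aryl group replaced on that carbonyl carbon, and both stayed within the scatter, as did the third step, a single substituent swap on an aromatic carbon. Every change of this kind so far has left the maximal response essentially where it was. On that basis no step beyond the scatter is expected; the expected step is a number 1 percentage points higher from compound 3 to compound 4 (within the scatter). Compound 4 is therefore estimated to give 66%, with a range from 55% to 77%.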

Compound 4, largest response reached (reported as efficacy), in percent of the reference or control that the assay uses: 64%
The estimate for compound 4 lay 2 percentage points above the measured number; the range from low to high includes it.
By their numbers in this assay, from the lowest: compounds 4, 3, 1 and 2 (each within the scatter of the next).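

Going by these compounds alone, the aryl group on the carbonyl carbon now carries two chlorine atoms, a kind of substituent the earlier compounds did not have, and in this assay replacing 3,4-dimethylphenyl with 3,5-dichlorophenyl gives a number 1 percentage points lower from compound 3 to compound 4 (within the scatter) as the result. The comparisons with the other two aryl groups agree, with a number 5 percentage points lower from compound 2 to compound 4 (within the scatter) in one case and a number 3 percentage points lower from compound 1 to compound 4 (within the scatter) in the other, so all four aryl groups on this carbonyl carbon give maximal responses that the measurement cannot separate, and none of the compounds shown goes against this. Nothing available explains why the maximal response stays within the scatter across these exchanges.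

All four compounds share the same core and carry a substituted phenyl group on the carbonyl carbon, leaving open what a saturated cyclohexyl ring, or a phenyl group bearing a carboxylic acid or an amine, would give at this place. Also open, going by these compounds, is whether the maximal response would stay as close if the change were made elsewhere in the shared core, for example by replacing the amide hydrogen with a methyl group.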